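A phenoxymethyl group replaces tert-butoxy in compound 3

This account rests on a few compounds, and the source may have more. Where it says the series, first, only, none or still open, it means among the compounds named here.

Values in a toxicity assay on KB cells (Homo sapiens) for cytotoxicity, read by fluorescence, with a stated time of 3 days; a higher number here means that more compound is needed for the effect, a lower number that less compound is needed:
Compound 1 `CCCCOC(=O)CNC(=O)[C@H](CSc1ccc([N+](=O)[O-])cc1[N+](=O)[O-])NC(=O)CC[C@H](NC(=O)OC)C(=O)OCCCC`: > 300 uM, a limit of the assay
Compound 2 `CCCCOC(=O)CNC(=O)[C@H](CSc1ccc([N+](=O)[O-])cc1[N+](=O)[O-])NC(=O)CC[C@H](NC(=O)CCC(C)C)C(=O)OCCCC`: 84 uM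
Compound 3 `CCCCOC(=O)CNC(=O)[C@H](CSc1ccc([N+](=O)[O-])cc1[N+](=O)[O-])NC(=O)CC[C@H](NC(=O)OC(C)(C)C)C(=O)OCCCC`: 70.4 uM

Among the compounds with values here, only two exact numbers exist, and they do not separate: a 1.2-fold lower number from compound 2 to compound 3 (0.08 log units; within the scatter). The third value is only a limit: the limit of > 300 uM in this assay, at which 1 of the 3 values shown sits. Both exact values stand apart from it: an at least 4.2-fold lower number from compound 1 to compound 3 (0.62 log units; beyond the scatter), and an at least 3.5-fold lower number from compound 1 to compound 2 (0.55 log units; beyond the scatter).

Compound 4 `CCCCOC(=O)CNC(=O)[C@H](CSc1ccc([N+](=O)[O-])cc1[N+](=O)[O-])NC(=O)CC[C@H](NC(=O)COc1ccccc1)C(=O)OCCCC` carries phenoxymethyl in place of tert-butoxy on a carbonyl carbon. Within the data shown here, the closest precedent is the exchange of isopentyl for tert-butoxy at this place, which stayed within the scatter. The step expected in this assay is therefore none beyond the scatter: a 1.2-fold lower number from compound 3 to compound 4 (0.07 log units; within the scatter). The estimated value for compound 4 is 60 uM, with an expected range of 25 uM to 150 uM.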

Compound 4, concentration for half-maximal effect: > 300 uM
Compound 4: a limit, no number; the forecaster's own chance of this, stated with the estimate: 8%; at least 5.0-fold (0.69 log units) between middle value and limit.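

In this assay, this place on the carbonyl carbon proves sensitive to the group it carries: isopentyl and tert-butoxy had stayed within the scatter of each other, yet phenoxymethyl, with its six-membered aromatic ring, gives an at least 4.2-fold higher number from compound 3 to compound 4 (0.62 log units; beyond the scatter) and an at least 3.5-fold higher number from compound 2 to compound 4 (0.55 log units; beyond the scatter). Compound 4 thus reads only as a limit, as compound 1 does, and the step between them cannot be read: the limit of > 300 uM in this assay, at which 2 of the 4 values shown sit.

Going by these compounds, it remains open whether the aromatic ring or the ether oxygen of phenoxymethyl goes with the higher number. A benzyl group on the same carbonyl carbon would separate the two.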